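Swapping the Aryl Ring on a Propylamine Aminothiazole Ligand

The source may hold more compounds than are shown below. What is called first, only, known or untested is meant among the compounds shown, and "the series" means these compounds.

Measured compounds:
compound 1, `CCCN(CCCCCc1cc(O)ccc1O)[C@H]1CCc2nc(N)sc2C1`: 0.78 nM
compound 2, `CCCN(CCC/C=C\c1ccc(O)c(OC)c1)C1CCc2nc(N)sc2C1`: 23.3 nM

Compound 1 is the stronger of the two compounds tested in an assay on HEK293 cells for displacement of a labelled ligand from D(3) dopamine receptor (Rattus norvegicus), with a stated time of 1 h; on this read-out lower numbers stand for stronger inhibition and higher numbers for weaker inhibition. Its value is the lowest of the two numbers, and compound 2 sits at a higher number, a difference that lies well beyond the scatter of repeated measurements. For the measured compounds named here, compound 2 differs from compound 1 in more than one place, so no single step between them can be drawn; what the two values show is only that the whole set of changes costs affinity.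

Compound 3, `CCCN(CCCCCc1ccc(O)c(OC)c1)[C@H]1CCc2nc(N)sc2C1`, is the next compound. Relative to compound 1 it carries 4-hydroxy-3-methoxyphenyl in place of 2,5-dihydroxyphenyl on a saturated chain carbon, five bonds along the chain from an amine nitrogen. The chain is kept saturated and the amine stereocentre is kept as in compound 1.

Compound 3 is expected to bind less tightly than compound 1, with a step of a 7.7-fold higher number from compound 1 to compound 3 (0.89 log units; beyond the scatter) in this assay, because compound 2 gives 23.3 nM while carrying the same 4-hydroxy-3-methoxyphenyl ring on a different chain. The estimate for compound 3 in this assay is 6 nM, within a range from 1.5 nM to 25 nM.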

Compound 3, inhibition constant: 1.57 nM
Beside the measured number, compound 3's estimate is 3.8-fold (0.58 log units) above it; the range from low to high includes it.
By their numbers in this assay, from the lowest: compounds 1 and 3 (each within the scatter of the next); then compound 2.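

In this assay, placing 4-hydroxy-3-methoxyphenyl in place of 2,5-dihydroxyphenyl on a saturated chain carbon, five bonds along the chain from an amine nitrogen, gives a 2.0-fold higher number from compound 1 to compound 3 (0.30 log units; within the scatter), so this position takes either ring without a difference that can be told from repeat measurement, even though a ring with 1 hydrogen-bond donor stands in for one with 2 hydrogen-bond donors. For the compounds shown here, this is the first comparison that isolates the ring, and it shows that the ring exchange alone does not reproduce the large gap in values seen between compound 1 and compound 2. No measurement shown here gives a reason for this tolerance.

Compound 2 differs from compound 3 in more than one place, so the steps for its unsaturated chain and its stereocentre cannot be read, and the source of its weaker binding stays unassigned. Also open, on these data alone, is whether the position would tolerate an unsubstituted phenyl ring, a ring bearing a carboxylic acid or an amine, or either ring on a longer chain, and whether the two rings would stay this close in value on the opposite stereocentre.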